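Lengthening the acyl chain on a shared amide core

The source may report more compounds than this note shows. Statements on the series, on what has been measured and on what is new or still open speak of the compounds shown alone.

Two amides on the same core have been measured in a functional assay on KYSE-450 cells (Homo sapiens) for inhibition, read by MTT assay, with a stated time of 48 h; a lower number here means a stronger inhibitor, a higher number a weaker inhibitor. Compound 1 `COc1ccc(CN(C(=O)C=C(C)C)c2cc(OC)c(OC)c(OC)c2)cc1O` gives 280 nM. Compound 2 `COc1ccc(CN(C(=O)C(C)C)c2cc(OC)c(OC)c(OC)c2)cc1O` gives 390 nM. Going by the values given here, the only step between measured compounds, a 1.4-fold higher number from compound 1 to compound 2 (0.14 log units; within the scatter), exchanges one small acyl group for another at the carbonyl carbon. On these two numbers compound 2 stands as the higher of the pair, yet its distance from compound 1 is within the scatter, so no order between them can be claimed.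

Compound 3 `COc1ccc(CN(C(=O)CCCCCl)c2cc(OC)c(OC)c(OC)c2)cc1O` has not yet been measured. It differs from compound 2 only at the carbonyl carbon: 4-chlorobutyl in place of isopropyl on a carbonyl carbon. Among the compounds with values here, the one measured step at this same position was within the scatter, and nothing here shows how a longer chain or a chlorine atom on it changes the number, so compound 3 is expected to sit close to compound 2, with the step of a 1.1-fold higher number from compound 2 to compound 3 (0.03 log units; within the scatter) estimated to stay within the scatter. The estimate for compound 3 in this assay is therefore 420 nM, in a range from 150 nM to 1200 nM.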

Compound 3, half-maximal inhibitory concentration: 770 nM
Beside the measured number, compound 3's estimate is 1.8-fold (0.26 log units) below it; the range from low to high includes it.
By their numbers in this assay, from the lowest: compounds 1, 2 and 3 (each within the scatter of the next, the first and the last beyond it).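

Going by these compounds alone, the 4-chlorobutyl amide gives the first step at this position, on a carbonyl carbon whose other neighbour is an amide-type nitrogen, that lies beyond the scatter in this assay (a 2.8-fold higher number from compound 1 to compound 3 (0.44 log units; beyond the scatter)), though the step is modest. Measured against isopropyl, the same group stays within the scatter (a 2.0-fold higher number from compound 2 to compound 3 (0.30 log units; within the scatter)), so compound 2 cannot be separated from either of the other two, and only the two ends of the series can be told apart. The position therefore accepts a longer, chlorine-bearing chain with only a modest shift in the number, and no measurement here explains that shift.

The compounds shown leave open whether the shift from compound 1 to compound 3 goes with the chlorine atom, with the length of the chain, or with the loss of the 2-methylprop-1-en-1-yl group, since all three differ together in that pair. A plain butyl chain, a longer chain ending in chlorine, or a chain of the same length ending in an amine or a carboxylic acid would each bear on that question.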